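This account rests on a few compounds, and the source may have more. Where it says the series, first, only, none or still open, it means among the compounds named here.

Compound 1 `O=C(O)CCNC(=O)c1ccc(C(Oc2ccc(-n3cc(C(F)(F)F)cn3)cc2)C2CC2)cc1` was tested in an ADME assay on microsomes from liver (Homo sapiens) for metabolic stability; a lower number here means slower removal, a higher number faster removal of the compound. Compound 1 gives only a limit there, < 8 mL/min/kg, which is the limit of < 8 mL/min/kg in this assay, at which 1 of the 3 values shown sits. Compound 2 `O=C(O)CCNC(=O)c1ccc(C(Oc2ccc(-n3cc(C(F)(F)F)cn3)cc2)C2CCC2)cc1`, with cyclobutyl in place of cyclopropyl, gives 26 mL/min/kg in this assay. That single-point change is an at least 3.2-fold higher number from compound 1 to compound 2 (0.51 log units; beyond the scatter). Compound 3 `CCCC(Oc1ccc(-n2cc(C)cn2)cc1)c1ccc(C(=O)NCCC(=O)O)cc1` gives 16 mL/min/kg in this assay. Compound 4 `CCCC(Oc1ccc(-n2cc(C(F)(F)F)cn2)cc1)c1ccc(C(=O)NCCC(=O)O)cc1` differs from compound 1 in one place: propyl in place of cyclopropyl on a saturated chain carbon bound to an aromatic carbon and an oxygen on an aromatic ring. Among the measured compounds shown here, no measured step covers propyl in place of cyclopropyl; the only comparable step is the one from compound 1 to compound 2, which moved the number upward. A modest rise beyond the scatter is therefore expected for compound 4, a step of an at least 2.2-fold higher number from compound 1 to compound 4 (0.35 log units; beyond the scatter). Compound 4 is estimated at 18 mL/min/kg, with a range from 8 mL/min/kg to 40 mL/min/kg.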

Compound 4, clearance: 16 mL/min/kg
Compound 4: middle estimate off by 1.1-fold (0.05 log units), on the high side; the measured number falls inside the stated range.
By their numbers in this assay, from the lowest: compounds 3, 4 and 2 (each within the scatter of the next). At a limit, below all of these: compound 1.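

Propyl in place of cyclopropyl gives an at least 2.0-fold higher number from compound 1 to compound 4 (0.30 log units; that floor lies within the scatter), and the number for compound 1 is a limit of the assay: the limit of < 8 mL/min/kg in this assay, at which 1 of the 4 values shown sits. Propyl in place of cyclobutyl gives a 1.6-fold lower number from compound 2 to compound 4 (0.21 log units; within the scatter), so in this assay these two groups are not told apart at this position. Trifluoromethyl in place of methyl on an aromatic carbon gives no change at the digits printed from compound 3 to compound 4 (within the scatter), the first reading of a change at a second place.

From the compounds shown here alone, the true size of the step from cyclopropyl stays open. So does how an amine or a longer chain in place of propyl would read.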